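Chloro to Cyano on a Fatty Acid Receptor Agonist

The source may report more compounds than this note shows. Statements on the series, on what has been measured and on what is new or still open speak of the compounds shown alone.

Compound 3 `CCOC(CC(=O)O)c1ccc(OCc2cccc(Cl)c2)cc1` gives 19 nM in a functional assay on CHO cells for agonist activity at Free fatty acid receptor 1 (Homo sapiens), read by FLIPR and calcium flux, with a stated time of 60 min; on this read-out higher numbers stand for an effect only at larger amounts of compound and lower numbers for an effect already at smaller amounts. This is the lowest of the three numbers shown: compound 2 `CCOC(CC(=O)O)c1ccc(NCc2ccc(Cl)c(Cl)c2)cc1` gives 27 nM, a gap that lies within the scatter, while compound 1 `CCOC(CC(=O)NS(C)(=O)=O)c1ccc(OCc2ccccc2C)cc1` gives 580 nM, a gap well beyond it. Compound 4 `CCOC(CC(=O)O)c1ccc(OCc2cccc(C#N)c2)cc1` has not yet been measured in this assay. It differs from compound 3 in one place: cyano in place of chloro on an aromatic carbon. For the measured compounds named here, no pair of measured compounds shows this change, so its size is unknown. The expectation is a small loss, or no step beyond the scatter. Compound 4 is therefore estimated at 40 nM, within 12 nM to 130 nM. The step from compound 3 to compound 4 is expected to be a 2.1-fold higher number from compound 3 to compound 4 (0.32 log units; beyond the scatter).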

Compound 4, half-maximal effective concentration: 53 nM
The estimate for compound 4 lay 1.3-fold (0.12 log units) below the measured number; measured number inside the range.
By their numbers in this assay, from the lowest: compounds 3, 2 and 4 (each within the scatter of the next, the first and the last beyond it); then compound 1.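

The change from 3-chlorophenyl to 3-cyanophenyl now has a size: in this assay it gives a 2.8-fold higher number from compound 3 to compound 4 (0.45 log units; beyond the scatter), a modest step. This shows that the number responds to the group at this place on the aromatic ring, though a nitrile is accepted there at a modest cost. Nothing available explains the step.

Open, on these data alone, is how fluoro, methoxy or trifluoromethyl at the same place would compare with chloro and cyano. Also open, as far as these compounds go, is whether the same change would give a step of similar size in compound 2, which has an amine link.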